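A few compounds are considered here, and "the series" means these few. Any claim that something is new, unique, unknown or untested is made for them only; others in the source may bear on it.

Compound 1 (`Fc1ccc(Sc2ncnc3[nH]cnc23)cc1`): 31600 nM
Compound 2 (`Clc1ccc(Sc2ncnc3[nH]cnc23)c(Cl)c1`): 21400 nM
Compound 3 (`c1ccc(Oc2ncnc3c2ncn3C2COc3ccccc3CO2)cc1`): 24700 nM

In a functional assay on MCF7 cells (Homo sapiens) for antiproliferative activity, read by sulforhodamine B assay, with a stated time of 3 days (on this read-out lower numbers stand for stronger inhibition and higher numbers for weaker inhibition), compound 3 gives 24700 nM and so stands within the scatter of both compound 1 and compound 2, which means the three numbers cannot be told apart. Compound 4 (`C=CCOc1ncnc2c1ncn2C1COc2ccccc2CO1`) keeps the rest of compound 3 but has allyl in place of phenyl on an oxygen on an aromatic ring. Among the measured compounds shown here, no two measured compounds differ in one place only, so the data offer no direct guide to this swap. No change beyond the scatter is therefore expected in this assay, in either direction. The estimated step is a 1.1-fold lower number from compound 3 to compound 4 (0.05 log units; within the scatter) for this swap. For compound 4 the expected value is 22000 nM with an estimated range from 9000 nM to 50000 nM in this test.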

Compound 4, half-maximal inhibitory concentration: 5040 nM
Estimate against measurement, compound 4: 4.4-fold (0.64 log units) above, outside the stated range (below it).
By their numbers in this assay, from the lowest: compound 4; then compounds 2, 3 and 1 (each within the scatter of the next).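

In this assay, putting allyl in place of phenyl on the oxygen gives a 4.9-fold lower number from compound 3 to compound 4 (0.69 log units; beyond the scatter), the first difference among these compounds that lies beyond the scatter. This shows that the group on this oxygen does affect the read-out, and that an aromatic ring is not needed there for activity. No measurement here explains the gain.

From the compounds shown here alone, it remains open whether the gain follows from losing the ring or from gaining the double bond. A saturated propyl or a methyl on the oxygen would help separate the two.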